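The source may report more compounds than this note shows. Statements on the series, on what has been measured and on what is new or still open speak of the compounds shown alone.

Compound 2 `Nc1nccc2c1ncn2[C@H]1C[C@H](O)[C@@H](CO)O1` gives 89% in a functional assay on EL4 cells (Mus musculus) for inhibition, tested at 100 uM (a lower number here means less inhibition, a higher number more inhibition at the concentration tested (going by the name of the read-out)), the lower of the two numbers at hand, while compound 1 `CCCCCCNc1[nH]ccc2ncnc1-2` gives 100% in this assay, a gap beyond the usual scatter. Compound 3 `CSc1nccc2c1ncn2[C@H]1C[C@H](O)[C@@H](CO)O1` differs from compound 2 in one place: methylsulfanyl in place of amino on an aromatic carbon. Among the measured compounds shown here, no measured pair shows what such a change does, so the size of the step is an expectation only. Compound 3 is expected to give 65% in this assay, within 25% to 95%. The step this estimate means, a number 24 percentage points lower from compound 2 to compound 3 (beyond the scatter), is expected to be a loss beyond the scatter.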

Compound 3, a percentage reported as inhibition, at one concentration (the size of the read-out at that concentration, not a potency): < 5%
Compound 3: only a limit was reported; the forecaster's own chance of this, stated with the estimate: 0%; middle value at least 60 percentage points away from the limit.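

On this aromatic carbon, next to the ring nitrogen, methylsulfanyl in place of amino gives a step of a number at least 84 percentage points lower from compound 2 to compound 3 (beyond the scatter) in this assay. Compound 3 stands at < 5%, a limit of the assay and not a number. Among the compounds shown here, the inhibition seen with compound 2 therefore does not survive this change, which the earlier compounds could not show, as no measured pair covered this position.

The compounds shown leave open whether a methylamino group, a methoxy group or a longer chain on this carbon would keep that inhibition. They also do not separate the loss of amino from the entry of sulfur.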